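Acetamido in place of chloro: an expected small step

The source may hold more compounds than are shown below. What is called first, only, known or untested is meant among the compounds shown, and "the series" means these compounds.

Of the compounds shown here, two have so far been measured in an ADME assay on MDCK cells (Canis lupus familiaris) for cytotoxicity, read by MTT assay, with a stated time of 72 h; on this read-out lower numbers stand for higher toxicity in this test and higher numbers for lower toxicity in this test. Compound 1 (`Cc1nc([N+](=O)[O-])cn1S(=O)(=O)c1ccc(Cl)cc1`) gives 578000 nM, and compound 2 (`Cc1nc([N+](=O)[O-])cn1CC(=O)NCc1ccccc1`) gives 77600 nM. Compound 1 therefore holds the higher of the two numbers, and the gap between them lies beyond the usual scatter. Compound 3 (`CC(=O)Nc1ccc(S(=O)(=O)n2cc([N+](=O)[O-])nc2C)cc1`) has not yet been measured. It keeps the core of compound 1 and carries acetamido in place of chloro on an aromatic carbon, para to a large group: acetamido in place of chloro on an aromatic carbon. Within the data shown here, the two measured compounds do not differ in one place only, so no measured step speaks directly to this change. In this assay, no step beyond the scatter is therefore expected, and the estimate stays anchored on compound 1 at 578000 nM, leaning slightly towards lower numbers. The expected change is a 1.3-fold lower number from compound 1 to compound 3 (0.11 log units; within the scatter), a step estimated to stay within the scatter. For compound 3 the estimated value is 450000 nM, with an expected range from 150000 nM to 1200000 nM.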

Compound 3, half-maximal cytotoxic concentration: 1030000 nM
Beside the measured number, compound 3's estimate is 2.3-fold (0.36 log units) below it; measured number inside the range.
By their numbers in this assay, from the lowest: compound 2; then compounds 1 and 3 (each within the scatter of the next).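

Among these compounds, at this place on the aromatic ring, para to a large group, compound 1 and compound 3 give the first comparison in this assay between compounds that differ in one place, and acetamido in place of chloro gives a 1.8-fold higher number from compound 1 to compound 3 (0.25 log units; within the scatter) within the usual scatter. Acetamido has more heavy atoms than chloro and brings a hydrogen-bond donor and a hydrogen-bond acceptor, yet this exchange leaves no step beyond the scatter in this test, so the position accepts at least this one larger replacement without a clear shift in the read-out. No measurement is at hand that would explain this outcome.

The compounds shown leave open whether the same holds for other groups at this place, such as an amine, a carboxylic acid or a longer chain, and whether any replacement there can move the number beyond the scatter. They also leave open how a change at this place behaves when the sulfonyl link of compound 1 and compound 3 is replaced by a different link to the shared core.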